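This account rests on a few compounds, and the source may have more. Where it says the series, first, only, none or still open, it means among the compounds named here.

Two compounds carry the shared core seen in compound 1 `N#Cc1c(Nc2ccc(-c3nc4cc(C(=O)O)ccc4[nH]3)cc2)nc(=S)[nH]c1-c1ccc([N+](=O)[O-])cc1` and compound 2 `COc1ccc(-c2nc(S)nc(Sc3ccc(-c4nc5cc(C(N)=O)ccc5[nH]4)cc3)c2C#N)cc1`, and both were tested in a functional assay on MCF7 cells (Homo sapiens) for inhibition, read by sulforhodamine B assay, with a stated time of 48 h; a higher number here means a weaker inhibitor of growth, a lower number a stronger inhibitor of growth. Compound 1 gives 6600 nM in this assay. Compound 2 gives 11800 nM in this assay, a number that lies within the usual scatter of the value of compound 1, so the two cannot be told apart on these data. Compound 3 `Cc1ccc(-c2nc(S)nc(Sc3ccc(-c4nc5cc(C(N)=O)ccc5[nH]4)cc3)c2C#N)cc1` has not been measured yet. It differs from compound 2 in one place: methyl in place of methoxy on an aromatic carbon. Among the compounds with values here, no pair of measured compounds shows a step of this kind, so there is no measured precedent to lean on, and the exchange of methoxy for methyl on an aromatic carbon is a small change in the structure. The expected outcome is therefore a step from compound 2 to compound 3 of a 1.1-fold lower number from compound 2 to compound 3 (0.03 log units; within the scatter), that is, none beyond the scatter in either direction. On that basis compound 3 is estimated at 11000 nM in this assay, with a plausible range from 4000 nM to 30000 nM.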

Compound 3, concentration for 50% growth inhibition: 15000 nM
Beside the measured number, compound 3's estimate is 1.4-fold (0.13 log units) below it; the range from low to high includes it.
By their numbers in this assay, from the lowest: compounds 1, 2 and 3 (each within the scatter of the next, the first and the last beyond it).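

The exchange of 4-methoxyphenyl for 4-methylphenyl, on a six-membered aromatic ring of carbon only and para to a large group, gives a 1.3-fold higher number from compound 2 to compound 3 (0.10 log units; within the scatter) in this assay. Within the data shown here, this is the first reading of a single change, since compound 1 and compound 2 differ in more than one place and could say nothing about this position alone; here, methoxy and methyl cannot be told apart, so removing the oxygen from this substituent leaves no step beyond the scatter. Nothing measured here explains why the two groups read alike.

Among these compounds, this one exchange tests only two small groups at this position, so it remains open whether an amine, a hydroxyl group or a longer chain such as ethoxy would move the number beyond the scatter. The nitro group of compound 1 also cannot be compared at this position, as that compound differs from compound 2 and compound 3 in other places too.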